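From a Substituted Benzamide to a Plain One

The source may hold more compounds than are shown below. What is called first, only, known or untested is meant among the compounds shown, and "the series" means these compounds.

Compound 1 `COc1cc(-c2nn(-c3cccc(NC(=O)c4cccc(C(F)(F)F)c4)c3)cc2-c2ccncc2)ccc1Cl` gives 46800 nM in a functional assay on BT-549 cells (Homo sapiens) for inhibition, read by sulforhodamine B assay, with a stated time of 48 h; a higher number here means a weaker inhibitor of growth, a lower number a stronger inhibitor of growth. Compound 2 `COc1cc(-c2nn(-c3cccc(NC(=O)c4ccc(Cl)c(C(F)(F)F)c4)c3)cc2-c2ccncc2)ccc1Cl` gives > 32500 nM in this assay. Compound 3 `O=C(Nc1cccc(-n2cc(-c3ccncc3)c(-c3ccc(Cl)c(O)c3)n2)c1)Nc1cc(C(F)(F)F)cc(C(F)(F)F)c1` gives 2120 nM in this assay.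

For compound 2 the value is a limit of the assay and not a number. Compound 1 and compound 2 share the same amide-linked core, while compound 3 carries a urea and a hydroxyl instead, and its number stands apart from the other two. Among the compounds with values here, the single step between measured neighbours, a step that the limit leaves unreadable from compound 1 to compound 2, cannot be read because of the limit of > 32500 nM in this assay, at which 1 of the 3 values shown sits.

Compound 4 `COc1cc(-c2nn(-c3cccc(NC(=O)c4ccccc4)c3)cc2-c2ccncc2)ccc1Cl` has not yet been measured. It differs from compound 2 by phenyl in place of 4-chloro-3-(trifluoromethyl)phenyl on a carbonyl carbon: the 4-chloro-3-(trifluoromethyl)phenyl, with its six-membered aromatic ring of carbon only, is replaced by a plain phenyl on the carbonyl carbon whose other neighbour is the amide-type nitrogen. No readable step bears on this change, so no shift beyond the scatter is expected; the estimate rests on where compound 1 and compound 2 stand. Compound 4 is therefore expected to give about 40000 nM, within 10000 nM to 120000 nM. The expected step is a step that the limit leaves unreadable from compound 2 to compound 4.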

Compound 4, concentration for total growth inhibition: > 100000 nM
Compound 4: only a limit was reported; the forecaster's own chance of this, stated with the estimate: 50%; middle value at least 2.5-fold (0.39 log units) from the limit.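

Within the data shown here, the first readable step at this position comes with hydrogen in place of trifluoromethyl on an aromatic carbon, an at least 2.1-fold higher number from compound 1 to compound 4 (0.32 log units; beyond the scatter). Among these two compounds, then, the benzamide ring with the trifluoromethyl goes with the lower number, and the plain phenyl gives up what little growth inhibition compound 1 shows. The value of compound 4 is a limit of the assay and not a number, so the true size of this step stays unknown: the limit of > 100000 nM in this assay, at which 1 of the 4 values shown sits.

Compound 2 and compound 4 both stand at limits, so the step between them cannot be read, and what the chloro adds to the trifluoromethyl stays unsettled. As far as these compounds go, whether an amine or a carboxylic acid on this ring in place of the trifluoromethyl would shift the number in this assay also remains open.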